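Removing One Chloro from the Dichlorophenyl Chalcone

The source may report more compounds than this note shows. Statements on the series, on what has been measured and on what is new or still open speak of the compounds shown alone.

Measured compounds:
compound 1 `O=C(COc1ccc(C(=O)/C=C/c2cccc(Cl)c2)cc1)N[C@H]1CCOC1=O`
compound 2 `O=C(COc1ccc(C(=O)/C=C/c2ccc(Cl)cc2Cl)cc1)N[C@H]1CCOC1=O`

In a functional assay on MCF7 cells (Homo sapiens) for antiproliferative activity, read by MTT assay, with a stated time of 72 h (on this read-out higher numbers stand for weaker inhibition and lower numbers for stronger inhibition), compound 1 gives 20900 nM and compound 2 gives 34400 nM. Compound 2 sits with compound 1 inside the scatter, as the step of a 1.6-fold higher number from compound 1 to compound 2 (0.22 log units; within the scatter) shows. Compound 3 `O=C(COc1ccc(C(=O)/C=C/c2ccccc2Cl)cc1)N[C@H]1CCOC1=O` differs from compound 2 by hydrogen in place of chloro on an aromatic carbon. Going by the values given here, only the step from compound 1 to compound 2 bears on this change, and it swapped one chlorophenyl for another without moving beyond the scatter; no measured step removes a chloro outright. The step expected here is a 1.1-fold lower number from compound 2 to compound 3 (0.06 log units; within the scatter). Compound 3 is therefore estimated at 30000 nM, expected to lie between 12000 nM and 75000 nM.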

Compound 3, half-maximal inhibitory concentration: 17400 nM
The estimate for compound 3 lay 1.7-fold (0.24 log units) above the measured number; measured number inside the range.
By their numbers in this assay, from the lowest: compounds 3, 1 and 2 (each within the scatter of the next).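

In this assay, taking away the chloro para to the large group, which turns 2,4-dichlorophenyl into 2-chlorophenyl, gives a 2.0-fold lower number from compound 2 to compound 3 (0.30 log units; within the scatter), so the outright loss of this chloro stays within the scatter. The 2-chlorophenyl and 3-chlorophenyl groups also cannot be told apart, with a 1.2-fold lower number from compound 1 to compound 3 (0.08 log units; within the scatter). No evidence is available that bears on these results. Still open, from the compounds shown here alone, is whether a methoxy group or an amine at this position would stay within the same scatter, and whether a phenyl group carrying no chloro at all would.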